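The source may hold more compounds than are shown below. What is called first, only, known or untested is meant among the compounds shown, and "the series" means these compounds.

Compound 1 `CC/C=C\C/C=C\C/C=C\C/C=C\C/C=C\C/C=C\CCC(=O)Oc1ccc(C(C)C)cc1C(C)C` sits in a functional assay on MDA-MB-231 cells (Homo sapiens) for inhibition, read by WST assay, with a stated time of 48 h (on this read-out higher numbers stand for weaker inhibition and lower numbers for stronger inhibition), at 7300 nM, the higher of the two numbers given; compound 3 `CC/C=C\C/C=C\C/C=C\C/C=C\C/C=C\C/C=C\CCC(=O)Nc1c(C(C)C)cccc1C(C)C` gives 3700 nM, a difference that lies within the usual scatter. Compound 2 `CC/C=C\C/C=C\C/C=C\C/C=C\C/C=C\C/C=C\CCC(=O)Oc1ccccc1` reaches only the limit of this assay, > 25000 nM. The step that bears on the question is an at least 3.4-fold higher number from compound 1 to compound 2 (0.53 log units; beyond the scatter), which shows that stripping the ring of its isopropyl groups weakens inhibition. Compound 4 `CC/C=C\C/C=C\C/C=C\C/C=C\C/C=C\C/C=C\CCC(=O)Oc1ccccc1C1CCCCC1` differs from compound 1 by 2-cyclohexylphenyl in place of 2,4-diisopropylphenyl on an oxygen next to a carbonyl group. Since the 2-cyclohexylphenyl still carries a carbon substituent on the ring, unlike the bare phenyl of compound 2, only a small step is expected, a 1.4-fold higher number from compound 1 to compound 4 (0.14 log units; within the scatter), toward a slightly weaker inhibition. Compound 4 is therefore estimated at 10000 nM, between 4000 nM and 25000 nM.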

Compound 4, half-maximal inhibitory concentration: 8400 nM
Compound 4: middle estimate off by 1.2-fold (0.08 log units), on the high side, within the range that was stated.
By their numbers in this assay, from the lowest: compounds 3, 1 and 4 (each within the scatter of the next, the first and the last beyond it). At a limit, above all of these: compound 2.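

In this assay, 2-cyclohexylphenyl in place of 2,4-diisopropylphenyl gives a 1.2-fold higher number from compound 1 to compound 4 (0.06 log units; within the scatter), so these two differently built carbon groups cannot be told apart at this oxygen. Cyclohexyl on the bare phenyl gives an at least 2.9-fold lower number from compound 2 to compound 4 (0.47 log units; beyond the scatter), which shows that this one group is enough to bring the reading within the measurable range. Compound 2 itself gives only a limit, not a number: the limit of > 25000 nM in this assay, at which 1 of the 4 values shown sits.

The compounds shown leave open how an amine or a carboxylic acid on this phenyl would read. They also leave open how 2-cyclohexylphenyl would read on the amide link of compound 3.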